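The compounds below may be only part of what the source reports. "The series", "measured", "known", "first", "only" and "open" are said of these compounds alone.

Compound 1, `CC(C)(C)n1cc(Nc2nc(N)cc(-c3cccc(-n4ccc5cc(C6CC6)cc(F)c5c4=O)c3CO)n2)cn1`: 5.7 10^-6 cm/s
Compound 2, `Nc1cc(-c2cccc(-n3ccc4cc(C5CC5)cc(F)c4c3=O)c2CO)nc(Nc2cnn(CC3CC3)c2)n1`: 6.1 10^-6 cm/s
Compound 3, `CC(C)n1cc(Nc2nc(N)cc(-c3cccc(-n4ccc5cc(C6CC6)cc(F)c5c4=O)c3CO)n2)cn1`: 3.7 10^-6 cm/s

The three measured compounds share one core and differ only in the group carried on an aromatic nitrogen. In an ADME assay on Caco-2 cells (Homo sapiens) for permeability (on this read-out lower numbers stand for lower permeability and higher numbers for higher permeability), compound 3 gives the lowest of the three numbers, yet the steps that separate it from its neighbours, a 1.5-fold lower number from compound 1 to compound 3 (0.19 log units; within the scatter) and a 1.6-fold lower number from compound 2 to compound 3 (0.22 log units; within the scatter), both lie within the scatter, so the three compounds cannot be told apart on this assay. The remaining step, a 1.1-fold higher number from compound 1 to compound 2 (0.03 log units; within the scatter), is likewise within the scatter.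

Compound 4, `CCn1cc(Nc2nc(N)cc(-c3cccc(-n4ccc5cc(C6CC6)cc(F)c5c4=O)c3CO)n2)cn1`, has not yet been measured. It differs from compound 3 in one place: hydrogen in place of methyl on a saturated chain carbon bound to an aromatic nitrogen and a saturated chain carbon. The step that bears most directly on it is a 1.5-fold lower number from compound 1 to compound 3 (0.19 log units; within the scatter), the same kind of removal of a methyl one bond further in, and it stayed within the scatter; the other two steps, which also only reshape this group, did the same. On this basis no step beyond the scatter is expected for compound 4 in this assay, with the number, if anything, drifting a little downward. Compound 4 is therefore estimated at 3.3 10^-6 cm/s, with a range from 1.8 10^-6 cm/s to 6 10^-6 cm/s, which means an expected step of a 1.1-fold lower number from compound 3 to compound 4 (0.05 log units; within the scatter).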

Compound 4, apparent permeability: 5.4 10^-6 cm/s
Beside the measured number, compound 4's estimate is 1.6-fold (0.21 log units) below it; the range from low to high includes it.
By their numbers in this assay, from the lowest: compounds 3, 4, 1 and 2 (each within the scatter of the next).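

Ethyl on the aromatic nitrogen adds a fourth group at this position, and in this assay all of its steps stay within the scatter: a 1.5-fold higher number from compound 3 to compound 4 (0.16 log units; within the scatter), a 1.1-fold lower number from compound 2 to compound 4 (0.05 log units; within the scatter) and a 1.1-fold lower number from compound 1 to compound 4 (0.02 log units; within the scatter). The earlier compounds shown here showed only one removal of a methyl from this group, a 1.5-fold lower number from compound 1 to compound 3 (0.19 log units; within the scatter), whereas the isopropyl to ethyl change gives a second one, and the two steps point in opposite directions, so no trend with the loss of methyl groups can be read from them. Tert-butyl, isopropyl, ethyl and cyclopropylmethyl therefore cannot be told apart in this assay, and no measured evidence is available to explain this result.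

All four groups shown are made of carbon and hydrogen alone, so it remains open whether a chain ending in an amine, a hydroxyl or a carboxylic acid on this aromatic nitrogen would give a step beyond the scatter. The compounds also leave open whether a longer chain, or hydrogen in place of the whole group, would stay within the scatter.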